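Thiophene substituent series: cytotoxicity on dog kidney cells

The source may hold more compounds than are shown below. What is called first, only, known or untested is meant among the compounds shown, and "the series" means these compounds.

Measured so far:
compound 1, `CCc1csc(CN[C@@H]2C[C@H]3C[C@@H]([C@H]2C)C3(C)C)c1`: 25000 nM
compound 2, `C[C@H]1[C@H](NCc2cc(Br)cs2)C[C@H]2C[C@@H]1C2(C)C`: 6250 nM
compound 3, `Cc1csc(CN[C@@H]2C[C@H]3C[C@@H]([C@H]2C)C3(C)C)c1`: 12500 nM

In an ADME assay on MDCK cells (Canis lupus familiaris) for cytotoxicity, read by microscopy, with a stated time of 48 h (a higher number here means that more compound is tolerated, a lower number that less compound is tolerated), compound 3 stands second highest of the three numbers; its nearest neighbour is compound 2 with 6250 nM and its furthest is compound 1 with 25000 nM, both within the scatter of it, so no order among the three can be read from these values.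

Compound 4, `C[C@H]1[C@H](NCc2cc(C3CCCCC3)cs2)C[C@H]2C[C@@H]1C2(C)C`, differs from compound 3 by cyclohexyl in place of methyl on an aromatic carbon. Going by these compounds, the measured steps at this aromatic carbon are a 4.0-fold lower number from compound 1 to compound 2 (0.60 log units; beyond the scatter) and a 2.0-fold higher number from compound 2 to compound 3 (0.30 log units; within the scatter); neither brings in a ring group, so the change is untested here. A step in this assay toward a lower number, of small to modest size, is expected: a 2.0-fold lower number from compound 3 to compound 4 (0.30 log units; within the scatter). Compound 4 is therefore estimated at 6250 nM, in the range 1560 nM to 25000 nM.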

Compound 4, minimum cytotoxic concentration: 780 nM
For compound 4 the middle estimate is 8.0-fold (0.90 log units) above the measured one; measured number below the stated range.
By their numbers in this assay, from the lowest: compound 4; then compounds 2, 3 and 1 (each within the scatter of the next, the first and the last beyond it).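

Cyclohexyl on this aromatic carbon lowers the number in this assay against each smaller group: a 16-fold lower number from compound 3 to compound 4 (1.20 log units; beyond the scatter), an 8.0-fold lower number from compound 2 to compound 4 (0.90 log units; beyond the scatter) and a 32-fold lower number from compound 1 to compound 4 (1.51 log units; beyond the scatter). This position is therefore not indifferent to what it carries, and compound 4 alone lies beyond the scatter of all the others.

Nothing at hand explains the drop. Going by these compounds, whether it follows the ring or the carbon count stays open, and a hexyl chain or a phenyl ring at this carbon would separate the two.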